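Swapping pyridin-3-yl for methyl on the sulfur side chain

This account rests on a few compounds, and the source may have more. Where it says the series, first, only, none or still open, it means among the compounds named here.

Measured so far:
- compound 1 `CNc1nc(C)c(-c2ccnc(Nc3ccc(OC)cc3OC)n2)s1`: 300 nM
- compound 2 `COc1ccc(Nc2nccc(-c3cn(C)c4ccccc34)n2)c(OC)c1`: 3410 nM
- compound 3 `COc1ccc(Nc2nccc(-c3sc(SCc4cccnc4)nc3C)n2)c(OC)c1`: 270 nM

In a functional assay on MV4-11 cells (Homo sapiens) for inhibition, read by resazurin assay, with a stated time of 72 h (a higher number here means a weaker inhibitor of growth, a lower number a stronger inhibitor of growth), compound 3 gives 270 nM, which cannot be told apart from compound 1 at 300 nM. Compound 2, at 3410 nM, lies well above both, beyond the scatter.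

The next compound is compound 4 `CCSc1nc(C)c(-c2ccnc(Nc3ccc(OC)cc3OC)n2)s1`. It differs from compound 3 only in its side chain: methyl in place of pyridin-3-yl on a saturated chain carbon bound to a sulfur. Put another way, ((pyridin-3-yl)methyl)sulfanyl becomes ethylsulfanyl.

Among the measured compounds shown here, only one measured step bears on this change. It is a 1.1-fold lower number from compound 1 to compound 3 (0.05 log units; within the scatter), where ((pyridin-3-yl)methyl)sulfanyl replaced methylamino on an aromatic carbon. That exchange left the number essentially unchanged, which suggests this part of the molecule tolerates different groups. However, no measured compound carries ethylsulfanyl, so the evidence is thin.

The expected step in this assay stays within the scatter, a 1.1-fold lower number from compound 3 to compound 4 (0.03 log units; within the scatter), and no real direction is claimed for it. For compound 4 the estimated value is 250 nM, with an expected range from 100 nM to 650 nM.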

Compound 4, concentration for 50% growth inhibition: 32400 nM
For compound 4 the middle estimate is 130-fold (2.11 log units) below the measured one, outside the stated range (above it).
By their numbers in this assay, from the lowest: compounds 3 and 1 (each within the scatter of the next); then compound 2; then compound 4.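

In this assay, methyl in place of pyridin-3-yl on a saturated chain carbon bound to a sulfur gives a 120-fold higher number from compound 3 to compound 4 (2.08 log units; beyond the scatter), so this side chain is far less forgiving than the matching numbers of compound 1 and compound 3 had suggested. Ethylsulfanyl in place of methylamino on an aromatic carbon gives a 110-fold higher number from compound 1 to compound 4 (2.03 log units; beyond the scatter), which shows that ethylsulfanyl does not stand in for methylamino here, although ((pyridin-3-yl)methyl)sulfanyl does. No measurement at hand accounts for this large loss of growth inhibition.

Going by these compounds, it remains open whether benzylsulfanyl, with a plain phenyl ring in place of pyridin-3-yl, would fall nearer compound 3 or compound 4, which would show whether the ring alone is enough or its nitrogen also counts. On these data alone, it is equally open where a longer chain such as butylsulfanyl would fall.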